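The source may report more compounds than this note shows. Statements on the series, on what has been measured and on what is new or still open speak of the compounds shown alone.

Compound 1 `CC1(C#N)CN(c2cc(COc3ccc(F)c(F)c3F)nc(-c3ccccn3)n2)C1`: 158 nM
Compound 2 `Fc1ccc(OCc2cc(OCC3CCC3)nc(-c3ccccn3)n2)c(F)c1F`: 12.6 nM

In a functional assay on cells for antagonist activity at Free fatty acid receptor 1 (Homo sapiens), read by TR-FRET and inositol phosphate accumulation, with a stated time of 2 h (a lower number here means a stronger inhibitor, a higher number a weaker inhibitor), compound 2 stands lowest of the two numbers measured. Compound 3 `Fc1ccc(OCc2cc(OCC3(F)COC3)nc(-c3ccccn3)n2)c(F)c1F` differs from compound 2 by 3-fluorooxetan-3-yl in place of cyclobutyl on a saturated chain carbon bound to an oxygen on an aromatic ring. Among the compounds with values here, the only measured step, a 13-fold lower number from compound 1 to compound 2 (1.10 log units; beyond the scatter), changed a different part of the shared core, so no measured step bears directly on this exchange. Since the saturated four-membered ring is kept and only its make-up changes, a modest shift toward a weaker number is expected, a 2.0-fold higher number from compound 2 to compound 3 (0.30 log units; within the scatter), not clearly beyond the scatter. Compound 3 is therefore estimated at 25 nM, between 8 nM and 80 nM.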

Compound 3, half-maximal inhibitory concentration: 63.1 nM
Beside the measured number, compound 3's estimate is 2.5-fold (0.40 log units) below it; low and high end bracket the measured number.
By their numbers in this assay, from the lowest: compound 2; then compound 3; then compound 1.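

In this assay, keeping a four-membered ring on this saturated chain carbon does not preserve the number: 3-fluorooxetan-3-yl in place of cyclobutyl gives a 5.0-fold higher number from compound 2 to compound 3 (0.70 log units; beyond the scatter). In place of 3-cyano-3-methylazetidin-1-yl on an aromatic carbon, (3-fluorooxetan-3-yl)methoxy still gives a 2.5-fold lower number from compound 1 to compound 3 (0.40 log units; beyond the scatter), so part of the gain seen with cyclobutylmethoxy remains. No measurement shown explains the change at this position. The new group brings in both a ring oxygen and a fluorine, and the compounds shown do not separate the two. An oxetan-3-yl group without fluorine, or a 3-fluorocyclobutyl group, would pull them apart.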